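A few compounds are considered here, and "the series" means these few. Any claim that something is new, unique, unknown or untested is made for them only; others in the source may bear on it.

Four compounds built on a closely related skeleton were compared in a functional assay on SH-SY5Y cells (Homo sapiens) for cytotoxicity, read by MTT assay, with stated times of 8 h, 30 min and 12 h, tested at 5 uM; on this read-out higher numbers stand for a stronger effect at the one concentration tested and lower numbers for a weaker effect. Compound 1, with the structure `N=C(NCc1ccccc1)[C@@H]1CCC(=O)N1Cc1ccccc1[N+](=O)[O-]`, gives 25.3% in this assay. Compound 2, with the structure `N=C(NCc1ccc(O)cc1)[C@@H]1CCC(=O)N1Cc1ccccc1[N+](=O)[O-]`, differs from it in one spot, described as hydroxy in place of hydrogen on an aromatic carbon, and gives 30.4%. The change made here is a number 5.1 percentage points higher from compound 1 to compound 2 (within the scatter), so the two values cannot be told apart with confidence.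

Compound 3, with the structure `N=C(NCc1ccccc1)[C@@H]1CCC(=O)N1Cc1ccc([N+](=O)[O-])cc1`, carries the same atoms as compound 1 joined in a different way; the difference between the two cores is not broken down here. In this assay compound 3 gives 25.6%.

Compound 4, with the structure `N=C(NCc1ccc(O)cc1)[C@@H]1CCC(=O)N1Cc1ccc([N+](=O)[O-])cc1`, stands to compound 3 exactly as compound 2 stands to compound 1: the change is hydroxy in place of hydrogen on an aromatic carbon, at a place described in the same words as before, so it is the same change on a different core. Since that change gave a number 5.1 percentage points higher from compound 1 to compound 2 (within the scatter), a step of similar size, a number 4.4 percentage points higher from compound 3 to compound 4 (within the scatter), is expected here. Compound 4 is therefore estimated at 30%, most likely between 20% and 40%.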

Compound 4, a percentage reported as activity, at one concentration (the size of the read-out at that concentration, not a potency): 34.5%
Beside the measured number, compound 4's estimate is 4.5 percentage points below it; measured number inside the range.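

The new step, a number 8.9 percentage points higher from compound 3 to compound 4 (within the scatter), is close in size to the earlier one on the other core, and the two cannot be told apart: the same change on two cores in this assay, a number 5.1 percentage points higher (within the scatter) from compound 1 to compound 2 and a number 8.9 percentage points higher (within the scatter) from compound 3 to compound 4, 3.8 percentage points apart, within the scatter of two such steps. Nothing here suggests that the change behaves differently on the core of compound 3 than on the core of compound 1, and moving the nitro group, seen in the step of a number 4.1 percentage points higher from compound 2 to compound 4 (within the scatter), also stays within the scatter. This does not prove that the change carries over reliably or that it raises the read-out at all, as each step alone is too small to be told from no change.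

The compounds shown leave open whether a methoxy group, an amine or a carboxylic acid in place of the hydroxy would give a step beyond the scatter. They also leave open whether the hydroxy change would give a similar step on any other core.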